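A Butoxy for Pentyl Swap on the Carbonyl

The source may hold more compounds than are shown below. What is called first, only, known or untested is meant among the compounds shown, and "the series" means these compounds.

In a functional assay on HT-29 cells (Homo sapiens) for antiproliferative activity, read by sulforhodamine B assay, with a stated time of 72 h (on this read-out higher numbers stand for weaker inhibition and lower numbers for stronger inhibition), compound 3 `CCCCCCCOc1ccc(CCC(CO)(CO)NC(=O)CCCCC)c2ccccc12` gives a value of 21900 nM and compound 1 `CCCCCCCCc1ccc(CCC(CO)(CO)NC(=O)CCCCC)c2ccccc12` gives 20300 nM on the same read-out. For the measured compounds named here, these are the only two numbers available, and they lie within the scatter of each other.

Compound 2 `CC(=O)NC(CO)(CO)CCc1ccc(O)c2ccccc12` returns only a limit of the assay (> 80000 nM).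

Compound 4 `CCCCCCCOc1ccc(CCC(CO)(CO)NC(=O)OCCCC)c2ccccc12` carries butoxy in place of pentyl on a carbonyl carbon. Going by the values given here, no measured step changes this carbonyl substituent, so the guidance is indirect. The nearest case is heptyloxy in place of octyl on an aromatic carbon, which also puts an oxygen into a chain and gave a 1.1-fold higher number from compound 1 to compound 3 (0.03 log units; within the scatter) as its result.

On the strength of that single step, no change beyond the scatter is expected in this assay. The expected step is a 1.1-fold lower number from compound 3 to compound 4 (0.04 log units; within the scatter) as estimated here.

For compound 4 the estimated value is 20000 nM (expected range 8000 nM to 50000 nM).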

Compound 4, half-maximal inhibitory concentration: 22400 nM
For compound 4 the middle estimate is 1.1-fold (0.05 log units) below the measured one; the range from low to high includes it.
By their numbers in this assay, from the lowest: compounds 1, 3 and 4 (each within the scatter of the next). At a limit, above all of these: compound 2.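

In this assay, for the compounds shown here, the step with butoxy in place of pentyl on a carbonyl carbon reads a 1.0-fold higher number from compound 3 to compound 4 (0.01 log units; within the scatter) and is the first measured change at this place. Turning (pentylcarbonyl)amino into (butoxycarbonyl)amino puts an oxygen into the chain and adds a hydrogen-bond acceptor, while the count of heavy atoms stays the same, and the read-out shows no change beyond the scatter. Nothing in the data given here bears on why this exchange leaves the number within the scatter.

On these data alone, this place rests on a single step, so it remains open whether a longer chain, a benzyloxy group or an amine on the carbonyl carbon would move the number beyond the scatter. As far as these compounds go, it is also open whether a carboxylic acid at the end of this chain would do so.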